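The source may report more compounds than this note shows. Statements on the series, on what has been measured and on what is new or still open speak of the compounds shown alone.

In an assay on CHO cells for displacement of a labelled ligand from adenosine receptor A1 (Homo sapiens), read by scintillation counting, tested at 10 uM (a higher number here means more inhibition at the concentration tested (going by the name of the read-out), a lower number less inhibition), the three measured compounds stand as follows:

Compound 1, `Cc1c(-c2ccccc2)sc(N)c1C(=O)c1ccc(Cl)cc1`: 1%
Compound 2, `COc1ccc(-c2sc(N)c(C(=O)c3ccc(Cl)cc3)c2C)cc1`: 1%
Compound 3, `Cc1c(Br)sc(N)c1C(=O)c1ccc(Cl)cc1`: 1%

Compound 1 is level with compounds 2 and 3 at the digits shown; its nearest neighbour is compound 2 and its furthest is compound 3, and neither gap is beyond the scatter. The step from compound 1 to compound 2, a methoxy in place of hydrogen on an aromatic carbon, gave no change at the digits printed from compound 1 to compound 2 (within the scatter). The step from compound 1 to compound 3, a bromo in place of phenyl on an aromatic carbon, gave no change at the digits printed from compound 1 to compound 3 (within the scatter), and the step from compound 2 to compound 3 gave no change at the digits printed from compound 2 to compound 3 (within the scatter). Every change tried on the shared core so far has left the inhibition where it was.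

Compound 4, `Nc1sc(-c2ccccc2)c(-c2ccccc2)c1C(=O)c1ccc(Cl)cc1`, has not yet been measured. It differs from compound 1 by phenyl in place of methyl on an aromatic carbon. Among the compounds with values here, no measured step alters this methyl, so none bears on it directly; the steps that exist, including the exchange of phenyl and bromo on the neighbouring ring carbon, all stayed within the scatter. The step from compound 1 to compound 4 is therefore expected to be a number 1 percentage points higher from compound 1 to compound 4 (within the scatter), that is, nothing beyond the scatter. For compound 4 the inhibition in this assay is estimated at 2%, within a range from 0% to 12%.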

Compound 4, a percentage reported as inhibition, at one concentration (the size of the read-out at that concentration, not a potency): 1%
For compound 4 the middle estimate is 1 percentage points above the measured one, within the range that was stated.
By their numbers in this assay, from the lowest: compounds 1, 2, 3 and 4 (each within the scatter of the next).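

In this assay, phenyl in place of methyl on an aromatic carbon gave no change at the digits printed from compound 1 to compound 4 (within the scatter) and is the only step shown at this position, which lies two ring bonds from the ring sulfur and next to the ring atom that bears a phenyl group. The result therefore extends what the other steps showed on the neighbouring ring carbon: here too, a methyl of 1 heavy atom and a phenyl of 6 heavy atoms, which brings a six-membered aromatic ring, leave the two compounds level, and compound 4 now carries phenyl groups on both ring carbons without standing apart from compounds 1, 2 and 3. None of the information available offers an explanation for this result.

The compounds shown leave open whether an amine or a carboxylic acid at this position, in place of methyl or phenyl, would stand apart from these four in this assay. They also leave open what a longer chain here would give, and whether any replacement of the amino group or of the group of 9 heavy atoms on the shared core would give a different reading.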